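The compounds below may be only part of what the source reports. "The series", "measured", "known", "first", "only" and "open" are said of these compounds alone.

Compound 1 `COc1ccc(NC(=O)c2csc(-c3cn(Cc4ccc(Cl)cc4)c4ccccc34)n2)cc1` gives 90900 nM in a functional assay on HeLa cells (Homo sapiens) for cytotoxicity, read by MTT assay, with a stated time of 48 h, in the presence of a further agent that is not named here; a higher number here means a weaker inhibitor, a lower number a stronger inhibitor.
Compound 2 `O=C(Nc1ccccc1)c1csc(-c2cn(Cc3ccc(Cl)cc3)c3ccccc23)n1` gives 32100 nM in this assay.
Compound 3 `COc1ccc2[nH]cc(-c3nc(C(=O)Nc4cc(OC)c(OC)c(OC)c4)cs3)c2c1` gives 9980 nM in this assay.

Of the three measured compounds, compound 3 has the lowest number in this assay; compound 2 lies nearest to it, with a number higher by an amount beyond the scatter, and compound 1 lies furthest, with a still higher number. Compound 4 `COc1cc(NC(=O)c2csc(-c3c[nH]c4ccc(F)cc34)n2)cc(OC)c1OC` is the unmeasured compound; it differs from compound 3 in one place, (fluoro in place of methoxy on an aromatic carbon). Within the data shown here, the only measured step that touches a methoxy on an aromatic carbon is a 2.8-fold lower number from compound 1 to compound 2 (0.45 log units; beyond the scatter), in which the methoxy is lost altogether, on a different part of the molecule, and the number falls modestly. Among the measured compounds shown here, no measured pair shows a methoxy exchanged for a fluoro, and none shows a change on the ring carrying the fused system. The evidence therefore supports only a weak expectation: a small lowering of the number, or no step beyond the scatter. Compound 4 is thus estimated to show a 1.4-fold lower number from compound 3 to compound 4 (0.15 log units; within the scatter) in this assay. Compound 4 is expected to give about 7000 nM in this assay, within a range from 2500 nM to 25000 nM.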

Compound 4, half-maximal inhibitory concentration: 48900 nM
Beside the measured number, compound 4's estimate is 7.0-fold (0.84 log units) below it; the whole stated range lies below it.
By their numbers in this assay, from the lowest: compound 3; then compounds 2, 4 and 1 (each within the scatter of the next, the first and the last beyond it).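

In this assay, fluoro in place of methoxy on the six-membered aromatic ring of carbon only, part of a fused or bridged system of two rings, gives a 4.9-fold higher number from compound 3 to compound 4 (0.69 log units; beyond the scatter), so this position does respond to the change, and the methoxy-bearing compound 3 has the lower number. Among these compounds, the only earlier step that removed a methoxy, a 2.8-fold lower number from compound 1 to compound 2 (0.45 log units; beyond the scatter), ran the other way, so across these two places, on different cores and with different incoming atoms, losing a methoxy has no single outcome. The information available offers no explanation for the rise in number at this position.

The compounds shown leave open whether the rise follows from the departure of the methoxy or from the arrival of the fluoro, as none of them carries a plain hydrogen at this position on the core of compound 3. As far as these compounds go, how a hydroxy, an ethoxy, a chloro or an amine at the same position would compare with the methoxy and the fluoro also remains open.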